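Amide nitrogen methylation from compound 2 to compound 4

The source may report more compounds than this note shows. Statements on the series, on what has been measured and on what is new or still open speak of the compounds shown alone.

For the measured compounds named here, in a functional assay on the whole organism for antagonist activity, with Mus musculus as the target (on this read-out higher numbers stand for an effect only at larger amounts of compound and lower numbers for an effect already at smaller amounts), compound 2 (`CC(=O)NCC#CCn1cncc1C`) gives 66 mg/kg, the only actual number so far. Compound 1 (`CC(=O)NCC#CCn1ccnc1`) reaches only a limit, > 100 mg/kg. Compound 3 (`CC(=O)N(C)CC#CCN1CCCC1`) also reaches only a limit, > 10 mg/kg.

Compound 4 (`CC(=O)N(C)CC#CCn1cncc1C`) departs from compound 2 at the acetamido group: methyl in place of hydrogen on an amide-type nitrogen, so acetamido becomes acetyl(methyl)amino. Going by the values given here, the only measured step, an at least 1.5-fold lower number from compound 1 to compound 2 (0.18 log units; that floor lies within the scatter), is methyl in place of hydrogen on an aromatic carbon. That is a different place, and the step does not clear the scatter, so it gives no size for the amide change. Among the compounds with values here, compound 3 also carries acetyl(methyl)amino, but no measured step connects it to compound 2. No shift beyond the scatter is therefore expected in this assay, and neither direction is favoured. The expected step is a 1.1-fold lower number from compound 2 to compound 4 (0.04 log units; within the scatter). Compound 4 is estimated at 60 mg/kg, with an expected range of 20 mg/kg to 180 mg/kg.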

Compound 4, dose for half-maximal effect: 6.6 mg/kg
Compound 4: the middle estimate sits 9.1-fold (0.96 log units) above what was measured; the measured number lies below the stated range.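

In this assay, for the compounds shown here, the amide-type nitrogen is the first position to give a step that can be sized, with methyl in place of hydrogen there producing a 10-fold lower number from compound 2 to compound 4 (1.00 log units; beyond the scatter). The earlier step on an aromatic carbon, an at least 1.5-fold lower number from compound 1 to compound 2 (0.18 log units; that floor lies within the scatter), gave no such reading. The amide hydrogen of compound 2 is therefore not needed for the effect in this assay, though nothing measured here accounts for the size of the step.

On these data alone, compound 3 also carries acetyl(methyl)amino, but its > 10 mg/kg is a limit, so whether the step carries over to that other core stays open. Also open, as far as these compounds go, is whether the step is particular to methyl, or whether an ethyl group or a longer chain on the same nitrogen would read the same way.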